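The compounds below may be only part of what the source reports. "The series", "measured", "known", "first", "only" and "open" are said of these compounds alone.

Two measured compounds share the same core and the same hydrazone-urea linkage. Compound 1 `O=C(N/N=C/c1ccc(Cl)cc1Cl)Nc1cccc2ccccc12` carries a 2,4-dichlorophenyl group, and compound 2 `C/C(=N\NC(=O)Nc1cccc2ccccc12)c1ccc(C)cc1` carries a 4-methylphenyl group with a methyl on the linking carbon. In a functional assay on the whole organism (strain Swiss albino) with Mus musculus as the target, with a stated time of 0.5 h (a higher number here means that more compound is needed for the effect, a lower number that less compound is needed), compound 1 gives 300 mg/kg, and in the same test compound 2 gives 300 mg/kg. On these numbers compound 1 stands level with compound 2; the two values are the same at the digits recorded, so nothing separates them beyond the usual scatter. Within the data shown here, no single-change step between measured compounds is available, so there is no measured step to lean on.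

Compound 3 `O=C(N/N=C/c1ccc(Cl)cc1)Nc1cccc2ccccc12` has not yet been tested. It differs from compound 1 in one place (hydrogen in place of chloro on an aromatic carbon).

Among the measured compounds shown here, with only two values to go on, both equal, there is no basis for expecting a shift in either direction in this assay. The step that this estimate implies, no change at the digits printed from compound 1 to compound 3 (within the scatter), is expected to be essentially none beyond the scatter. Compound 3 is therefore expected to give about 300 mg/kg, within a range from 150 mg/kg to 600 mg/kg.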

Compound 3, minimum effective dose: 300 mg/kg
Compound 3: middle estimate and measured number agree at the digits printed; measured number inside the range.
By their numbers in this assay, from the lowest: compounds 1, 2 and 3 (each within the scatter of the next).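

Among these compounds, compounds 1 and 3 form the first pair here that differs in only one place, so the effect of a single chloro group can be read directly: in this assay the change from 2,4-dichlorophenyl to 4-chlorophenyl gives no change at the digits printed from compound 1 to compound 3 (within the scatter) and nothing more. At this position, on an aromatic carbon ortho to a large group and meta to a chloro group, the chloro can therefore be replaced by hydrogen with no shift that this test can separate from the scatter, so this one heavy atom is not needed to keep the reading where it stands. Nothing measured on these compounds offers an explanation for this result.

From the compounds shown here alone, it remains open whether a different group at this position, such as a methoxy group, an amine or a carboxylic acid, would move the number in either direction. A plain phenyl group in place of 4-chlorophenyl would also show whether the remaining chloro group can be replaced by hydrogen with equally little effect.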